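Dimethylpyridinyl Ether Analogue and the Expected Solubility Shift

The source may report more compounds than this note shows. Statements on the series, on what has been measured and on what is new or still open speak of the compounds shown alone.

compound 1 `Cc1ccc(Oc2ccc3nc(COc4cccc(C(=O)O)c4)n(C)c3n2)cc1F` — 5.2 ug/mL
compound 2 `Cc1ccc(Oc2cc3c(cn2)nc(COc2cccc(C(=O)O)c2)n3C)cc1` — 360 ug/mL
compound 3 `Cn1c(COc2cccc(C(=O)O)c2)nc2ccc(Oc3ccccn3)cc21` — 62 ug/mL

Of the compounds shown here, three have been measured in a physicochemical assay for solubility, read by HPLC, measured as thermodynamic solubility, with a stated time of 4 h, at pH 6.8; on this read-out lower numbers stand for lower solubility and higher numbers for higher solubility. Compound 3 stands second highest of the three numbers: compound 2 sits above it, beyond the scatter, while compound 1 sits below it, also beyond the scatter. Compound 4 `Cc1ccc(C)c(Oc2ccc3nc(COc4cccc(C(=O)O)c4)n(C)c3c2)n1` differs from compound 3 in one place: 3,6-dimethylpyridin-2-yl in place of pyridin-2-yl on an oxygen on an aromatic ring. For the measured compounds named here, no measured pair shows this change, so its effect cannot be read from the measured compounds. Compound 4 is expected to show a downward step in this assay, estimated as a 3.1-fold lower number from compound 3 to compound 4 (0.49 log units; beyond the scatter), of moderate size and beyond the scatter. The estimate for compound 4 in this assay is 20 ug/mL, within a range from 5 ug/mL to 70 ug/mL.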

Compound 4, solubility: 85 ug/mL
Beside the measured number, compound 4's estimate is 4.3-fold (0.63 log units) below it; measured number outside the range, above it.
By their numbers in this assay, from the lowest: compound 1; then compounds 3 and 4 (each within the scatter of the next); then compound 2.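

In this assay, 3,6-dimethylpyridin-2-yl in place of pyridin-2-yl on this oxygen gives a 1.4-fold higher number from compound 3 to compound 4 (0.14 log units; within the scatter). This first step at the position shows that the larger group leaves the number within the scatter, so the read-out does not separate these two groups here. Nothing available explains this result. The compounds shown leave open whether 3-methylpyridin-2-yl or 6-methylpyridin-2-yl would read the same way. They also leave open whether an amine or a methoxy group on this pyridine ring would produce a step beyond the scatter.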